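From Sulfanyl to Benzylamino on the Shared Core

The source may report more compounds than this note shows. Statements on the series, on what has been measured and on what is new or still open speak of the compounds shown alone.

Compounds measured so far:
compound 1, `CCOC(=O)[C@H](CCC(=O)O)NC(=O)c1ccc(Sc2nc3cc(N)cc(N)c3nc2-c2ccccc2)cc1`, 63100 nM
compound 2, `Nc1cc(N)c2nc(-c3ccccc3)c(Sc3ccc(F)cc3)nc2c1`, 47900 nM
compound 3, `CCOC(=O)[C@H](CCC(=O)O)NC(=O)c1ccc(CNc2nc3cc(N)cc(N)c3nc2-c2ccccc2)cc1`, < 100000 nM

In a functional assay on SNB-75 cells (Homo sapiens) for inhibition, read by sulforhodamine B assay, with a stated time of 48 h (a higher number here means a weaker inhibitor of growth, a lower number a stronger inhibitor of growth), compound 2 gives 47900 nM. Compound 1 gives 63100 nM in this assay, a number that sits within the scatter of that of compound 2, so the two cannot be told apart. For compound 3, this assay reports only a limit, < 100000 nM, and not a number; this is the limit of < 100000 nM in this assay, at which 1 of the 3 values shown sits. Compound 4, `Nc1cc(N)c2nc(-c3ccccc3)c(NCc3ccc(F)cc3)nc2c1`, is not yet measured. It differs from compound 2 in one place: (4-fluorobenzyl)amino in place of (4-fluorophenyl)sulfanyl on an aromatic carbon. For the measured compounds named here, no step between measured compounds is available to gauge this change, so the expected step is a 1.4-fold higher number from compound 2 to compound 4 (0.13 log units; within the scatter), not clearly beyond the scatter. Compound 4 is therefore expected to give 65000 nM in this assay, with a range from 22000 nM to 160000 nM.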

Compound 4, concentration for total growth inhibition: 5010 nM
Estimate against measurement, compound 4: 13-fold (1.11 log units) above, outside the stated range (below it).
By their numbers in this assay, from the lowest: compound 4; then compounds 2 and 1 (each within the scatter of the next).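

In this assay, the aromatic carbon next to the ring nitrogen proves sensitive to this change: (4-fluorobenzyl)amino in place of (4-fluorophenyl)sulfanyl gives a 9.6-fold lower number from compound 2 to compound 4 (0.98 log units; beyond the scatter). This is the first step that can be read among the compounds shown, and it lies beyond the scatter. Nothing measured here accounts for it.

For compound 3, the assay reports only a limit, < 100000 nM, so a like exchange on that larger compound stays unread. Also open, as far as these compounds go, is whether a plain amine at this position, without the 4-fluorobenzyl group, would keep the lower number.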